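Chain-end phenyl on the shared core: expected effect

This account rests on a few compounds, and the source may have more. Where it says the series, first, only, none or still open, it means among the compounds named here.

Two numbers are known so far in a functional assay on the whole organism (strain C57B/6) with Mus musculus as the target, in the maximal electroshock model; on this read-out higher numbers stand for an effect only at larger amounts of compound and lower numbers for an effect already at smaller amounts. Compound 1 `CCCCCCOc1ccc(-n2cnnc2CCCC)cc1` gives 13.6 mg/kg, and compound 2 `CCCCCCOc1ccc(-n2cnnc2-c2ccccc2F)cc1` gives 20.2 mg/kg; the step of a 1.5-fold higher number from compound 1 to compound 2 (0.17 log units; within the scatter) is within the scatter. Compound 3 `CCCCCCOc1ccc(-n2cnnc2CCc2ccccc2)cc1` differs from compound 1 in one place: phenyl in place of ethyl on a saturated chain carbon, two bonds along the chain from an aromatic carbon. Among the compounds with values here, no measured step touches that place; the only measured step, a 1.5-fold higher number from compound 1 to compound 2 (0.17 log units; within the scatter), swaps 2-fluorophenyl for butyl on an aromatic carbon and stays within the scatter, so for compound 3 no change beyond the scatter is expected in this assay, that is a 1.2-fold higher number from compound 1 to compound 3 (0.07 log units; within the scatter). For compound 3 the estimate is 16 mg/kg, range 8 mg/kg to 32 mg/kg.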

Compound 3, dose for half-maximal effect: 27.4 mg/kg
Compound 3: middle estimate off by 1.7-fold (0.23 log units), on the low side, and the stated range covers the measured number.
By their numbers in this assay, from the lowest: compounds 1, 2 and 3 (each within the scatter of the next).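

In this assay, within the data shown here, the first step at this place on the saturated chain, phenyl in place of ethyl, gives a 2.0-fold higher number from compound 1 to compound 3 (0.30 log units; within the scatter), so a chain-end phenyl is tolerated at this place within the scatter. Set against the aryl group directly on the aromatic carbon, phenethyl gives a 1.4-fold higher number from compound 2 to compound 3 (0.13 log units; within the scatter), so the two are not told apart in this assay.

Open, going by these compounds, is whether an amine or a carboxylic acid on the chain-end phenyl, or a longer chain carrying it, would give a step beyond the scatter. What lies behind these numbers has no support from any evidence at hand.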